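From 4-methylphenyl to 2-fluorophenyl at the ring amine

The compounds below may be only part of what the source reports. "The series", "measured", "known", "first", "only" and "open" are said of these compounds alone.

compound 1 `COC(=O)CC/C(C)=C/Cc1c(OC)c(C)c2c(c1OCC#CCN1CCN(c3ccc(C)cc3)CC1)C(=O)OC2` — > 50000 nM
compound 2 `COC(=O)CC/C(C)=C/Cc1c(OC)c(C)c2c(c1OCC#CCN1CCC(C(=O)OC)CC1)C(=O)OC2` — > 50000 nM
compound 3 `COC(=O)CC/C(C)=C/Cc1c(OC)c(C)c2c(c1OCC#CCN1CCC(Cc3ccccc3)CC1)C(=O)OC2` — > 50000 nM

Of the compounds shown here, three of this set have been measured in a functional assay on HT-29 cells (Homo sapiens) for inhibition, read by sulforhodamine B assay; on this read-out higher numbers stand for weaker inhibition and lower numbers for stronger inhibition. Compound 1 reaches only the limit of the assay and returns > 50000 nM. Compound 2 also sits at the limit, with > 50000 nM. Compound 3 likewise gives the limit > 50000 nM. The step that the two limits leave unreadable from compound 2 to compound 3 has both of its ends at the limit and cannot be read. Compound 1 therefore stands where every measured compound stands, at the limit of > 50000 nM in this assay, at which 3 of the 3 values shown sit, with no number that would rank it against the others.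

Compound 4 `COC(=O)CC/C(C)=C/Cc1c(OC)c(C)c2c(c1OCC#CCN1CCN(c3ccccc3F)CC1)C(=O)OC2` differs from compound 1 by 2-fluorophenyl in place of 4-methylphenyl on an amine nitrogen in a ring. Within the data shown here, no measured step touches this amine nitrogen in the ring; the one step that was measured, a step that the two limits leave unreadable from compound 2 to compound 3, concerns a different ring and is itself unreadable. Among the measured compounds shown here, the only evidence bearing on the change is the limit of > 50000 nM in this assay, at which 3 of the 3 values shown sit, which gives no size for any step. For this change the expected step is a number no higher from compound 1 to compound 4 (the limit leaves the size open), which means compound 4 is expected to stay at the limit. For compound 4 the estimate is 50000 nM, with a range from 15000 nM to 200000 nM.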

Compound 4, half-maximal inhibitory concentration: > 50000 nM
Compound 4: no number, only a limit (the forecaster's own chance of this, stated with the estimate: 85%); the middle value sits exactly at the limit.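

In this assay compound 4 gives > 50000 nM, which is a limit of the assay and not a number. Compound 1 also sits at a limit, so no step can be read between compound 1 and compound 4. The compounds shown leave open how these groups rank against one another, and what the evidence offers is only this: the limit of > 50000 nM in this assay, at which 4 of the 4 values shown sit.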